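The source may hold more compounds than are shown below. What is called first, only, known or untested is meant among the compounds shown, and "the series" means these compounds.

In an ADME assay on HeLa cells (Homo sapiens) for cytotoxicity, read by MTT assay, with a stated time of 48 h (a higher number here means a weaker inhibitor, a lower number a stronger inhibitor), compound 2 `O=[N+]([O-])c1cc(CSc2nnnn2Cc2ccccc2)cc([N+](=O)[O-])c1` gives > 30000 nM, which is a limit of the assay rather than a number. Compound 1 `O=[N+]([O-])c1ccc(CSc2nnnn2C2CCCCC2)c([N+](=O)[O-])c1` likewise reaches only a limit, at > 30000 nM. Both measured values sit at the limit of > 30000 nM in this assay, at which 2 of the 2 values shown sit, so neither compound shows any measurable inhibition. Compound 3 `O=[N+]([O-])c1cc(CSc2nnnn2C2CCCCC2)cc([N+](=O)[O-])c1` differs from compound 2 by cyclohexyl in place of benzyl on an aromatic nitrogen. Compound 1 carries the same cyclohexyl group and still gives only a limit. The expected step is a step that the limit leaves unreadable from compound 2 to compound 3, none beyond the scatter. Compound 3 is therefore estimated at 45000 nM, within 20000 nM to 120000 nM, most likely reported again as a limit.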

Compound 3, half-maximal inhibitory concentration: > 30000 nM
Compound 3: a limit, no number (the forecaster's own chance of this, stated with the estimate: 85%); the middle value lies beyond the limit too.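

No step can be read from compound 2 to compound 3 because both values are limits: the limit of > 30000 nM in this assay, at which 3 of the 3 values shown sit. The compounds shown leave open which change to the shared core, if any, would give a readable value.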